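The source may report more compounds than this note shows. Statements on the series, on what has been measured and on what is new or still open speak of the compounds shown alone.

Compound 1 `CCCCCCCCCO[C@@H]1[C@@H](N)[C@@H](OCC(O)CNCCN)O[C@H](CN)[C@H]1OCCCCCCCCC` was examined in a toxicity assay on the whole organism (J774 cells) for cytotoxicity, with Mus musculus as the target, read by MTT assay, with a stated time of 24 h, tested at 10 uM (a lower number here means a stronger effect, a higher number a weaker effect of the compound at the concentration tested), where compound 1 gives 87.5%. Two other compounds share the same kind of measurement: compound 2 `CCCCCCCCCO[C@@H]1[C@@H](N)[C@@H](O[C@H]2[C@H](O)[C@@H](OCCCCCCCCC)[C@H](N)C[C@@H]2N)O[C@H](CN)[C@H]1O` gives 78.4% in this assay, and compound 3 `NC[C@H]1O[C@H](O[C@H]2[C@H](O)[C@@H](O)[C@H](N)C[C@@H]2N)[C@H](N)[C@@H](OCc2ccc3ccccc3c2)[C@@H]1OCc1ccc2ccccc2c1` gives 79.1%. The number for compound 1 sits within the usual scatter of both of these, so the three compounds cannot be told apart on these readings; all of them leave most of the cells alive at the concentration tested.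

The next compound, compound 4 `CCCCCCCCCO[C@@H]1[C@@H](N)[C@@H](OC[C@H](O)CN=[N+]=[N-])O[C@H](CN)[C@H]1OCCCCCCCCC`, is built from compound 1 by one change: 2-azido-1-hydroxyethyl in place of 2-((2-aminoethyl)amino)-1-hydroxyethyl on a saturated chain carbon bound to an oxygen on a saturated carbon. For the measured compounds named here, no pair of measured compounds differing in exactly this way exists, so there is no measured step to lean on. Given that the three measured numbers all lie close together, the step from compound 1 to compound 4 is expected to be small, a number 2.5 percentage points lower from compound 1 to compound 4 (within the scatter), with no direction beyond the scatter. On that basis compound 4 is estimated to give 85% in this assay, within a range from 70% to 98%.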

Compound 4, a percentage reported as activity, at one concentration (the size of the read-out at that concentration, not a potency): 62.2%
For compound 4 the middle estimate is 22.8 percentage points above the measured one; the measured number lies below the stated range.
By their numbers in this assay, from the lowest: compound 4; then compounds 2, 3 and 1 (each within the scatter of the next).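

In this assay, putting 2-azido-1-hydroxyethyl in place of 2-((2-aminoethyl)amino)-1-hydroxyethyl on a saturated chain carbon bound to an oxygen on a saturated carbon gives a number 25.3 percentage points lower from compound 1 to compound 4 (beyond the scatter). For the compounds shown here, this shows that the group at this place can change the reading, and that this change gives a stronger effect on the cells at the concentration tested, which the earlier compounds, with no step between them, could not show. No measurement offered here explains the step.

One step cannot tell whether the lower number follows the departure of the 2-((2-aminoethyl)amino)-1-hydroxyethyl group, the arrival of the azide, or the defined stereocentre that compound 4 carries in this group. From the compounds shown here alone, how a simple primary amine, a carboxylic acid or a longer chain at this place would read remains open.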